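A few compounds are considered here, and "the series" means these few. Any claim that something is new, unique, unknown or untested is made for them only; others in the source may bear on it.

Among the compounds with values here, in an ADME assay on MT2 cells (Homo sapiens) for cytotoxicity, read by XTT assay, with a stated time of 4 days (a higher number here means that more compound is tolerated, a lower number that less compound is tolerated), compound 2 `Cc1nc(C(NC(=O)C(=O)Nc2ccc(Cl)cc2)C2CCCCN2C)sc1CCO` gives 88000 nM, the only true number among the three values available. Compound 1 `Cc1nc(C(NC(=O)C(=O)Nc2ccc(Cl)cc2)C2CCNCC2)sc1CCO` reads > 78500 nM, which is a limit of the assay and not a number. Compound 3 `Cc1ccc(NC(=O)C(=O)NC(c2nc(C)c(CO)s2)C2CCCCN2)cc1F` reads > 88000 nM, which is also a limit. Compound 4 `CC(=O)N1CCCCC1C(NC(=O)C(=O)Nc1ccc(Cl)cc1)c1nc(C)c(CCO)s1` carries acetyl in place of methyl on an amine nitrogen in a ring. Within the data shown here, the only measured step is a step that the limit leaves unreadable from compound 1 to compound 2, and it concerns a different change, so it offers no size to carry over. With compound 2 at 88000 nM as the sole anchor, no step beyond the scatter is expected in this assay. The expected change is a 1.0-fold lower number from compound 2 to compound 4 (0.02 log units; within the scatter). Compound 4 is estimated at 85000 nM, with an expected range of 45000 nM to 160000 nM.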

Compound 4, half-maximal cytotoxic concentration: > 84000 nM
Compound 4: no number, only a limit; the forecaster's own chance of this, stated with the estimate: 45%; the middle value does not contradict the limit.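

Compound 4 gives only a limit and not a number, so the steps to it from compound 1 and compound 2 cannot be read. The compounds shown leave open whether acetyl in place of methyl on the ring nitrogen changes how much compound is tolerated.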